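Aryl swap on the pyrrolidine of compound 1

This account rests on a few compounds, and the source may have more. Where it says the series, first, only, none or still open, it means among the compounds named here.

Measured compounds:
compound 1 `CC(C)[C@H](NC(=O)CCN(C)C)c1cccc(F)c1N1CCN(C(=O)[C@@H]2CN(C(C)C)C[C@H]2c2ccc(Cl)cc2)CC1`: 103%
compound 2 `Cc1ccc(N2CCN(C(=O)[C@@H]3CNC[C@H]3c3ccc(Cl)cc3)CC2)c([C@@H](NC(=O)CCN(C)C)C(C)C)c1`: 72%

In a functional assay on CHO cells with Melanocortin receptor 4 (Homo sapiens) as the target, read by cAMP accumulation (a higher number here means a larger maximal response, a lower number a smaller maximal response), compound 1 gives 103%, the higher of the two numbers; compound 2 gives 72%, a gap beyond the scatter. Among the measured compounds shown here, no single-site step between measured compounds exists, so the effect of the change below rests on no precedent.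

Compound 3 `CC(C)[C@H](NC(=O)CCN(C)C)c1cccc(F)c1N1CCN(C(=O)[C@@H]2CN(C(C)C)C[C@H]2c2ccc(C(F)(F)F)c(F)c2)CC1` differs from compound 1 by 3-fluoro-4-(trifluoromethyl)phenyl in place of 4-chlorophenyl on a saturated ring carbon. Intrinsic activity is expected to stay near that of compound 1, so the step of a number 8 percentage points lower from compound 1 to compound 3 (within the scatter) is expected to be small, if anything downward, and not clearly beyond the scatter. For compound 3 the estimate is 95%, within 75% to 110%.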

Compound 3, intrinsic activity: the largest response reached, in percent of the reference agonist's: 47%
The estimate for compound 3 lay 48 percentage points above the measured number; the measured number lies below the stated range.
By their numbers in this assay, from the lowest: compound 3; then compound 2; then compound 1.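

In this assay the step for 3-fluoro-4-(trifluoromethyl)phenyl in place of 4-chlorophenyl is a number 56 percentage points lower from compound 1 to compound 3 (beyond the scatter) with the rest of the molecule unchanged. The aryl group on this saturated ring carbon therefore strongly affects the maximal response and cannot be exchanged freely in this series. No available measurement explains the drop.

Going by these compounds, the fluorine and the trifluoromethyl group enter together, so their separate contributions remain open. The response with 4-(trifluoromethyl)phenyl or 3-fluorophenyl at this position would show which part accompanies the drop.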